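Thiophene-fused series: aryl for cyclohexyl at the thiophene carbon

A few compounds are considered here, and "the series" means these few. Any claim that something is new, unique, unknown or untested is made for them only; others in the source may bear on it.

Measured compounds:
compound 1 `CC#C[C@@H](Cc1nnn[nH]1)c1ccc(OCc2ccc3scc(C4CCCCC4)c3c2)cc1` gives 16 nM
compound 2 `CC#C[C@@H](Cc1nnn[nH]1)c1ccc(OCc2ccc3sc(F)c(-c4ccc(OCCOC)cc4C)c3c2)cc1` gives 24 nM
compound 3 `CC#C[C@@H](Cc1nnn[nH]1)c1ccc(OCc2cc(F)c3scc(-c4ccc(OC)cc4C)c3c2)cc1` gives 39 nM

All three numbers come from a functional assay on cells for agonist activity at Free fatty acid receptor 1 (Rattus norvegicus), read by FLIPR and calcium flux; on this read-out higher numbers stand for an effect only at larger amounts of compound and lower numbers for an effect already at smaller amounts. Compound 1 carries the lowest number of the three; its gap to compound 2 lies within the scatter, its gap to compound 3 beyond it. No pair of these compounds differs in one place only, so no single step is isolated.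

Compound 4 `CC#C[C@@H](Cc1nnn[nH]1)c1ccc(OCc2ccc3scc(-c4ccccc4C(F)(F)F)c3c2)cc1` has not yet been measured. Against compound 1 the change is 2-(trifluoromethyl)phenyl in place of cyclohexyl on an aromatic carbon. Compounds 2 and 3, which carry a substituted phenyl at the same place, give numbers near that of compound 1; a small step is therefore expected for compound 4, namely a 1.6-fold higher number from compound 1 to compound 4 (0.19 log units; within the scatter), a modestly higher number within or just beyond the scatter. The estimate for compound 4 is 25 nM, with a range from 9 nM to 70 nM.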

Compound 4, half-maximal effective concentration: 2 nM
Beside the measured number, compound 4's estimate is 13-fold (1.10 log units) above it, and the stated range ends above it.
By their numbers in this assay, from the lowest: compound 4; then compounds 1, 2 and 3 (each within the scatter of the next, the first and the last beyond it).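

In this assay, among the compounds shown here, the swap on the aromatic carbon two ring bonds from the ring sulfur gives an 8.0-fold lower number from compound 1 to compound 4 (0.90 log units; beyond the scatter) and is the first step isolated at one place. This position therefore responds to the group it carries, and 2-(trifluoromethyl)phenyl and cyclohexyl are separated beyond the scatter. Nothing measured here bears on why the number falls.

The step changes the ring and adds the trifluoromethyl together, so their shares stay unresolved. A plain phenyl at this carbon would separate the two.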